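A few compounds are considered here, and "the series" means these few. Any claim that something is new, unique, unknown or untested is made for them only; others in the source may bear on it.

Measured in a functional assay on HL-60 cells (Homo sapiens) for cytotoxicity, read by luminescence and CellTiter-Glo, with a stated time of 3 days; on this read-out higher numbers stand for weaker inhibition and lower numbers for stronger inhibition:
- compound 1 `O=C(Nc1ccc(OC(F)(F)F)cc1)c1cc(F)ccc1O`: 850 nM
- compound 2 `O=C(Nc1ccc(OC(F)(F)F)c(Cl)c1)c1cc(F)ccc1O`: 550 nM

Compound 2 gives 550 nM in this assay, and compound 1 gives 850 nM, so the two numbers lie within the scatter of each other. Compound 3 `O=C(Nc1ccc(OC(F)(F)F)c(Cl)c1)c1cc(Cl)ccc1O` departs from compound 2 as follows: chloro in place of fluoro on an aromatic carbon. This is chloro in place of fluoro on an aromatic carbon, para to a hydroxy group. Among the measured compounds shown here, no measured step makes this exchange. For the measured compounds named here, the only step available, a 1.5-fold lower number from compound 1 to compound 2 (0.19 log units; within the scatter), is chloro in place of hydrogen on an aromatic carbon, and it stays within the scatter. On that slender evidence, no change beyond the scatter is expected in this assay. The expected step is a 1.4-fold lower number from compound 2 to compound 3 (0.14 log units; within the scatter), which leaves no firm direction. For compound 3 the estimated value is 400 nM, with an expected range from 170 nM to 900 nM.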

Compound 3, half-maximal inhibitory concentration: 450 nM
Beside the measured number, compound 3's estimate is 1.1-fold (0.05 log units) below it; measured number inside the range.
By their numbers in this assay, from the lowest: compounds 3, 2 and 1 (each within the scatter of the next).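

In this assay, chloro in place of fluoro on the aromatic carbon para to a hydroxy group gives a 1.2-fold lower number from compound 2 to compound 3 (0.09 log units; within the scatter). Among the compounds shown here, this is the first look at this position, and here the two halogens cannot be told apart beyond the scatter. The earlier exchange at another place on the core, a 1.5-fold lower number from compound 1 to compound 2 (0.19 log units; within the scatter), also stays within the scatter, so neither halogen exchange shown so far separates the compounds, and nothing at hand accounts for where these numbers lie.

Only halogens stand at this position in the compounds shown, so it remains open whether a methoxy group, an amine or a carboxylic acid there would move the number beyond the scatter. Also open is what the hydroxy group and the amide hydrogen contribute, as both are present in all the compounds shown.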